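The compounds below may be only part of what the source reports. "The series", "measured", "known", "first", "only" and "open" are said of these compounds alone.

Of the compounds shown here, three on one shared core have numbers so far. In a functional assay on MDA-MB-436 cells (Homo sapiens) for antiproliferative activity, read by MTT assay, with a stated time of 48 h (on this read-out higher numbers stand for weaker inhibition and lower numbers for stronger inhibition), compound 1 (`CN1CCN(c2ccc(-c3cc4c(N5CCN(C(=O)Nc6ccc(C#N)cc6)CC5)ncnc4s3)cc2)CC1`) gives 5010 nM and compound 2 (`CN1CCN(c2ccc(-c3cc4c(N5CCN(C(=O)Nc6ccccc6F)CC5)ncnc4s3)cc2)CC1`) gives 14300 nM while compound 3 (`CN1CCN(c2ccc(-c3cc4c(N5CCN(C(=O)Nc6cccc(F)c6)CC5)ncnc4s3)cc2)CC1`) gives 18300 nM on the same read-out. Compound 3 therefore sits at the high end of these numbers, though not alone. Moving the fluorine gives a 1.3-fold higher number from compound 2 to compound 3 (0.11 log units; within the scatter) and stays within the scatter. The steps of a 2.9-fold higher number from compound 1 to compound 2 (0.46 log units; beyond the scatter) and a 3.7-fold higher number from compound 1 to compound 3 (0.56 log units; beyond the scatter) go beyond the scatter but remain modest.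

The next step leads to compound 4 (`CC(C)c1cccc(C(C)C)c1NC(=O)N1CCN(c2ncnc3sc(-c4ccc(N5CCN(C)CC5)cc4)cc23)CC1`) and puts 2,6-diisopropylphenyl in place of 3-fluorophenyl on an amide-type nitrogen. Among the measured compounds shown here, all three measured steps change the group at this same place, so they are the only guide. None of them includes an alkyl-bearing aryl group, and the data give no direction for this change. The largest change seen here is modest (a 3.7-fold higher number from compound 1 to compound 3 (0.56 log units; beyond the scatter)), so a step of no more than that size is expected in this assay, most likely none beyond the scatter. The estimated step is a 1.5-fold lower number from compound 3 to compound 4 (0.18 log units; within the scatter) and it carries a wide margin. Compound 4 is estimated at 12000 nM with an expected range (4000 nM to 35000 nM).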

Compound 4, half-maximal inhibitory concentration: 11300 nM
Compound 4: middle estimate off by 1.1-fold (0.03 log units), on the high side; the range from low to high includes it.
By their numbers in this assay, from the lowest: compound 1; then compounds 4, 2 and 3 (each within the scatter of the next).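

In this assay, the change from 3-fluorophenyl to 2,6-diisopropylphenyl on the amide-type nitrogen, which takes the group from 7 to 12 heavy atoms, stays within the scatter at a 1.6-fold lower number from compound 3 to compound 4 (0.21 log units; within the scatter), and the comparison with the other fluorinated aryl group does too, at a 1.3-fold lower number from compound 2 to compound 4 (0.10 log units; within the scatter). Neither fluorine nor a small aryl group is therefore needed to stay level with compounds 2 and 3 at this position, and across these three compounds the heavy-atom count of the group gives no order in the numbers. The 4-cyanophenyl group of compound 1 now stands apart from a third, structurally different neighbour, with a 2.3-fold higher number from compound 1 to compound 4 (0.35 log units; beyond the scatter) still modest, and no measurement available here accounts for any of these steps.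

From the compounds shown here alone, it remains open whether the separation of compound 1 belongs to the nitrile itself or to where it sits on the aryl ring, a question that 3-cyanophenyl and 4-fluorophenyl at this place would address. Also open, going by these compounds, is how an aryl group carrying an amine or a carboxylic acid would compare with compound 1 at 5010 nM.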